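Tert-butyl for isobutyl on a double-bonded nitrogen

The compounds below may be only part of what the source reports. "The series", "measured", "known", "first", "only" and "open" are said of these compounds alone.

Three compounds of the shared core have numbers in a functional assay for inhibition, with Rattus norvegicus as the target; on this read-out lower numbers stand for stronger inhibition and higher numbers for weaker inhibition. Compound 1 `CC(C)C/N=c1\c(O)c(O)\c1=N/Cc1ccc(C#N)cc1` gives 10200 nM; compound 2 `CCC(C)(C)/N=c1\c(O)c(O)\c1=N/Cc1ccc(SC)cc1` gives 5600 nM; compound 3 `Cc1cc(Cl)cc(Cl)c1C/N=c1\c(O)c(O)\c1=N/C(C)C(C)(C)C` gives 9800 nM. Compound 1 has the highest of the three numbers, yet its gaps to compound 3 and to compound 2 both lie within the scatter, so no order among them can be claimed. Compound 4 `CC(C)(C)/N=c1\c(O)c(O)\c1=N/Cc1ccc(C#N)cc1` is not yet measured in this assay. It differs from compound 1 in one place: tert-butyl in place of isobutyl on a double-bonded nitrogen. Among the measured compounds shown here, no measured pair isolates this change, and the three measured numbers, with different branched groups on that nitrogen, stay within the scatter of one another. The step from compound 1 to compound 4 is therefore expected to be small in either direction, a 1.3-fold lower number from compound 1 to compound 4 (0.11 log units; within the scatter). Compound 4 is expected to give about 8000 nM in this assay, between 3000 nM and 22000 nM.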

Compound 4, half-maximal inhibitory concentration: 270 nM
Beside the measured number, compound 4's estimate is 30-fold (1.47 log units) above it, and the stated range ends above it.
By their numbers in this assay, from the lowest: compound 4; then compounds 2, 3 and 1 (each within the scatter of the next).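

In this assay the step of a 38-fold lower number from compound 1 to compound 4 (1.58 log units; beyond the scatter) is large, though the two compounds have the same atoms and only the joining of the four carbons differs. Among the compounds shown here, the place on the double-bonded nitrogen is therefore sensitive to the choice between isobutyl and tert-butyl, which the earlier compounds, differing in more than one place, could not show. Nothing available accounts for the size of this step. From the compounds shown here alone, whether a cyclopropyl ring or a longer chain on this nitrogen keeps the lower number stays open. So does whether the step holds without the nitrile.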